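This account rests on a few compounds, and the source may have more. Where it says the series, first, only, none or still open, it means among the compounds named here.

The shared core is carried unchanged by compound 1 `C/C(=C\COC(=O)NC(C)(C)C)C1=CC(=O)C(C)(C)O1`, compound 2 `C/C(=C\C=C/C1CCCCC1)C1=CC(=O)C(C)(C)O1` and compound 3 `C/C(=C\C=C\c1ccccc1)C1=CC(=O)C(C)(C)O1`; the three differ only in the side chain attached to it. In a functional assay on MOLT-4F cells (Homo sapiens) for inhibition (a lower number here means a stronger inhibitor, a higher number a weaker inhibitor), compound 1 gives 6.1 ug/mL. In this assay compound 2 gives 7.1 ug/mL, a number within the scatter of that of compound 1, so the two cannot be ordered. In this assay compound 3 gives 14 ug/mL, and the gap between compound 1 and compound 3 lies beyond the scatter. Compound 1 thus stands at the low end of the three numbers, separated beyond the scatter from compound 3 alone. Going by the values given here, the three side chains are of unrelated make-up, so no comparison of measured compounds that differ in a single place is available.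

Compound 4 `C/C(=C\COC(=O)NCc1ccccc1)C1=CC(=O)C(C)(C)O1` is not yet measured. It departs from compound 1 by one change: benzyl in place of tert-butyl on an amide-type nitrogen. Among the compounds with values here, nothing measured touches the substituent on the amide-type nitrogen, so the step has no precedent. The expectation is a step of modest size, a 1.2-fold lower number from compound 1 to compound 4 (0.09 log units; within the scatter), with no clear direction and probably within the scatter. For compound 4 the estimated value in this assay is 5 ug/mL, with a range from 2 ug/mL to 15 ug/mL.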

Compound 4, half-maximal inhibitory concentration: 6 ug/mL
Compound 4: middle estimate off by 1.2-fold (0.08 log units), on the low side, and the stated range covers the measured number.
By their numbers in this assay, from the lowest: compounds 4, 1, 2 and 3 (each within the scatter of the next, the first and the last beyond it).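

In this assay, going by these compounds alone, benzyl in place of tert-butyl on an amide-type nitrogen gives a 1.0-fold lower number from compound 1 to compound 4 (0.01 log units; within the scatter), the first comparison of two compounds that differ in one place. At this position, going from a group with no ring to one carrying a six-membered aromatic ring of carbon only therefore leaves the number unresolved from that of compound 1, so this pair gives no ordering of the two groups. No measurement at hand bears on why the two groups cannot be told apart.

Still open, as far as these compounds go, is whether other groups on the same nitrogen would also stay within the scatter of compound 1, for example phenethyl as a longer chain, or a benzyl group carrying a carboxylic acid or an amine. Within the data shown here, also open is what the rest of the side chain contributes, since compound 2 and compound 3 differ from compound 1 in more than one place and so give no step that bears on this nitrogen.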